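A few compounds are considered here, and "the series" means these few. Any claim that something is new, unique, unknown or untested is made for them only; others in the source may bear on it.

Measured so far:
- compound 1, `[N-]=[N+]=NCc1cn([C@H]2C[C@H](O)[C@@H](CO)O2)c(=O)[nH]c1=O`: 124000 nM
- compound 2, `CN(C)c1ncnc2c1ncn2COCCO`: > 200000 nM, which is a limit of the assay rather than a number

The read-out here is an ADME assay on L1210/0 cells (Mus musculus) for cytotoxicity, with a stated time of 48 h; a higher number here means a weaker inhibitor, a lower number a stronger inhibitor. Compound 1 is the only one of the two with a numerical result in this assay, and the other result is described by the limit of > 200000 nM in this assay, at which 1 of the 2 values shown sits. Nothing further can be read from the pair, since the value of compound 2 is a limit and not a number.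

The unmeasured compound 3, `CCCCCC#Cc1cn([C@H]2C[C@H](O)[C@@H](CO)O2)c(=O)[nH]c1=O`, shares the core of compound 1 and differs from it in one place: hept-1-yn-1-yl in place of azidomethyl on an aromatic carbon. No measured step of this kind is available among the compounds shown, so the direction can only be guessed. The step expected a 2.1-fold lower number from compound 1 to compound 3 (0.32 log units; beyond the scatter) is a modest move toward a lower number, close to the usual scatter, and a result that turns out to be a limit cannot be ruled out. Compound 3 is therefore estimated at 60000 nM in this assay, with a range from 10000 nM to 200000 nM.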

Compound 3, half-maximal inhibitory concentration: > 200000 nM
Compound 3: a limit, no number; the forecaster's own chance of this, stated with the estimate: 25%; at least 3.3-fold (0.52 log units) between middle value and limit.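

Placing hept-1-yn-1-yl in place of azidomethyl on this aromatic carbon gives, in this assay, an at least 1.6-fold higher number from compound 1 to compound 3 (0.20 log units; that floor lies within the scatter). Among these compounds, this is the first measured change at this position, and it shows that a long carbon chain ending the alkyne does not bring the number lower than that of compound 1, so the larger group offers no gain in this read-out. Compound 3 gives > 200000 nM, which is a limit of the assay and not a number, so the real size of the step stays unknown, and such results are common in this small set: the limit of > 200000 nM in this assay, at which 2 of the 3 values shown sit.

The compounds shown leave open whether any group on this aromatic carbon can give a clearly lower number than compound 1, for example a shorter chain such as ethyl, an aminomethyl group or a carboxylic acid. They also leave open how much of the result depends on the alkyne itself rather than on chain length, a question that a saturated heptyl chain at the same place would address.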